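The source may report more compounds than this note shows. Statements on the series, on what has been measured and on what is new or still open speak of the compounds shown alone.

Measured so far:
compound 1, `CC(C)n1ncc2c(C(=O)Nc3ccccc3)cccc21`, 19700 nM
compound 2, `CC(C)n1ncc2c(C(=O)NCc3cn(-c4cccc(Br)c4)nn3)cccc21`, > 40000 nM

In a functional assay on MCF7 cells (Homo sapiens) for inhibition, read by MTT assay, with a stated time of 72 h (a lower number here means a stronger inhibitor, a higher number a weaker inhibitor), compound 1 gives 19700 nM. For compound 2 the result is a limit of this assay, > 40000 nM, and not a number, as noted in the limit of > 40000 nM in this assay, at which 1 of the 2 values shown sits. Among the compounds with values here, compound 2 thus stands at the edge of what this assay can report, and the two measured values together give no step from which a direction could be read.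

Compound 3, `CC(C)n1ncc2c(C(=O)NCc3cn(-c4ccccc4F)nn3)cccc21`, carries 2-fluorophenyl in place of 3-bromophenyl on an aromatic nitrogen. Within the data shown here, no measured pair shows the effect of such a change, so nothing here points to either direction. The step that the limit leaves unreadable from compound 2 to compound 3 is expected to be none beyond the scatter, with compound 3 remaining at or near the limit of this assay. Compound 3 is estimated at 45000 nM, within 15000 nM to 150000 nM, and a limit rather than a number is the more likely outcome.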

Compound 3, half-maximal inhibitory concentration: > 40000 nM
Compound 3 gave a limit, no number (the forecaster's own chance of this, stated with the estimate: 65%); the middle value is on the limit's open side.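

In this assay compound 2 and compound 3 each give a limit and not a number, and no new step can be read between them: the limit of > 40000 nM in this assay, at which 2 of the 3 values shown sit.

Left open is whether 2-fluorophenyl and 3-bromophenyl on the aromatic nitrogen differ at all in this assay on this core.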